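The compounds below may be only part of what the source reports. "The series", "measured", "known", "first", "only" and "open" are said of these compounds alone.

Measured so far in an ADME assay on microsomes from liver (Homo sapiens) for metabolic stability, read by LC-MS, with a stated time of 10 min; on this read-out higher numbers stand for a more stable compound and lower numbers for a less stable compound:
- compound 1 `C[C@@H]1CN(c2cccc3c2C[C@H](CN(C)[C@H]2CCCc4cccnc42)NC3)C[C@H](C)N1`: 100%
- compound 2 `Cc1cnc(CN(C)C[C@H]2Cc3c(cccc3N3CCNCC3)CN2)c(C)c1`: "not determined" (no result reported)
- compound 3 `CN(C[C@@H]1Cc2c(cccc2N2CCNCC2)CN1)[C@H]1CCCc2cccnc21`: 94.2%

In this assay only two of these compounds have a number. Compound 1 gives 100% and compound 3 gives 94.2%, which lie within the scatter of each other. Both sit close to the top of the scale, while compound 2 offers no number for comparison.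

The next compound to be tested is compound 4 `CN(C[C@H]1Cc2c(cccc2N2CCNC(C)(C)C2)CN1)[C@H]1CCCc2cccnc21`. It carries 3,3-dimethylpiperazin-1-yl in place of the 3,5-dimethylpiperazin-1-yl of compound 1 on an aromatic carbon: 3,3-dimethylpiperazin-1-yl in place of 3,5-dimethylpiperazin-1-yl on an aromatic carbon. Within the data shown here, no measured pair in this set isolates such an exchange, so the expectation rests only on the two numbers available. An estimated a number 7 percentage points lower from compound 1 to compound 4 (within the scatter) is expected to stay within the scatter, with no firm direction, though the top of the scale leaves little room for a rise. For compound 4 the expected value is 93%, with an estimated range from 78% to 100%.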

Compound 4, percent of the compound remaining: 100%
The estimate for compound 4 lay 7 percentage points below the measured number, within the range that was stated.
By their numbers in this assay, from the lowest: compounds 3, 1 and 4 (each within the scatter of the next).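

Among these compounds, this is the first step that can be read at this position: in this assay, placing 3,3-dimethylpiperazin-1-yl in place of 3,5-dimethylpiperazin-1-yl on an aromatic carbon gives no change at the digits printed from compound 1 to compound 4 (within the scatter). The two methyl groups can therefore sit on a single ring carbon, and the group can lose its 2 defined stereocentres, with compound 4 still at 100%, the top of the scale. Nothing shown gives a reason for this result.

From the compounds shown here alone, how a morpholine or an open-chain diamine would read on the same aromatic carbon remains open. Going by these compounds, with both compounds at the top of the scale, it is also open whether the two dimethylpiperazines would separate in a more demanding test of stability.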